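A few compounds are considered here, and "the series" means these few. Any claim that something is new, unique, unknown or untested is made for them only; others in the source may bear on it.

In an assay on HL-60 cells for agonist activity at vitamin D3 receptor (Homo sapiens), read by microscopy, with a stated time of 96 h (on this read-out higher numbers stand for an effect only at larger amounts of compound and lower numbers for an effect already at smaller amounts), three compounds built on one shared core have been measured. Compound 1 `CCOC(=O)CN(C)C(=O)c1ccc(C(CC)(CC)c2ccc(OCC(=O)C(C)(C)C)c(C)c2)n1CC` yields only a limit of the assay, > 50000 nM, and no number. Compound 2 `C#CC(C)OC(=O)c1ccc(C(CC)(CC)c2ccc(OCC(=O)C(C)(C)C)c(C)c2)n1CC` gives 210 nM, while compound 3 `C#CCCOC(=O)c1ccc(C(CC)(CC)c2ccc(OCC(=O)C(C)(C)C)c(C)c2)n1CC` gives 28800 nM. Of the two numbers in hand, compound 3 stands highest; its nearest neighbour is compound 2, and the step between them is a 140-fold higher number from compound 2 to compound 3 (2.14 log units; beyond the scatter), brought about by but-3-yn-1-yl in place of 1-methylprop-2-yn-1-yl on an oxygen next to a carbonyl group.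

Compound 4 `CCn1c(C(=O)OCc2ccc(F)cc2)ccc1C(CC)(CC)c1ccc(OCC(=O)C(C)(C)C)c(C)c1` has not yet been measured. It differs from compound 3 in one place: 4-fluorophenyl in place of propargyl on a saturated chain carbon bound to an oxygen next to a carbonyl group. The measured steps that bear on this are those touching the same part of the molecule: a 140-fold higher number from compound 2 to compound 3 (2.14 log units; beyond the scatter) shows that a small rearrangement of the group on the ester oxygen shifts the read-out widely, and an at least 230-fold lower number from compound 1 to compound 2 (2.37 log units; beyond the scatter) shows a comparable swing when the attachment at the carbonyl is exchanged. Going by the values given here, none of the measured compounds carries a ring at this position, so the direction cannot be read directly from them. With compound 3 already at the top of the measured numbers, a lower number is expected more likely than a higher one, but with wide uncertainty. Compound 4 is therefore estimated at 4000 nM, within 300 nM to 40000 nM, which would mean an expected step of a 7.2-fold lower number from compound 3 to compound 4 (0.86 log units; beyond the scatter).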

Compound 4, half-maximal effective concentration: 9500 nM
Beside the measured number, compound 4's estimate is 2.4-fold (0.38 log units) below it, within the range that was stated.
By their numbers in this assay, from the lowest: compound 2; then compound 4; then compound 3. At a limit, above all of these: compound 1.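

Placing a ring at this position is compatible with a measurable effect: 4-fluorophenyl in place of propargyl on the saturated chain carbon gives a 3.0-fold lower number from compound 3 to compound 4 (0.48 log units; beyond the scatter) in this assay, yet the same ester remains well behind the branched 1-methylprop-2-yn-1-yl ester, with a 45-fold higher number from compound 2 to compound 4 (1.66 log units; beyond the scatter). Among the three esters, the size of the group on the oxygen therefore does not set the order on its own, as the group with the ring lies between the two alkynes, which differ from each other only in how their atoms are arranged. Exchanging ((ethoxycarbonyl)methyl)(methyl)amino for (4-fluorobenzyl)oxy on the carbonyl carbon gives an at least 5.2-fold lower number from compound 1 to compound 4 (0.72 log units; beyond the scatter), and that figure is only a floor. Compound 1 stands at a limit of the assay and not at a number: the limit of > 50000 nM in this assay, at which 1 of the 4 values shown sits.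

As far as these compounds go, what a plain benzyl group would give at this place, and with it what the fluorine adds, stays open. Also open, from the compounds shown here alone, are a free carboxylic acid at this carbonyl and a 1-phenylethyl ester, which would show whether the branching of compound 2 has a similar effect when the group carries a ring.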